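Hydrogen in place of hydroxy in compound 2

A few compounds are considered here, and "the series" means these few. Any claim that something is new, unique, unknown or untested is made for them only; others in the source may bear on it.

Measured in a functional assay on the whole organism for inhibition, with Rattus norvegicus as the target (a higher number here means a weaker inhibitor, a lower number a stronger inhibitor), so far
compound 1 `O=C1ON=C(c2cccs2)/C1=C/c1ccc(O)cc1` gives 4200 nM
compound 2 `O=C1ON=C(c2cccs2)/C1=C/c1ccccc1O` gives 5700 nM
compound 3 `O=C1ON=C(c2cccs2)/C1=C/c1ccc(O)c(O)c1` gives 3400 nM

Compound 2 at 5700 nM lies within the usual scatter of both compound 1 and compound 3, so these three cannot be ranked. The next compound to consider is compound 4 `O=C1ON=C(c2cccs2)/C1=C/c1ccccc1`, which has hydrogen in place of hydroxy on an aromatic carbon, ortho to a large group (hydrogen in place of hydroxy on an aromatic carbon). Among the compounds with values here, only one measured step bears on this change. It runs the opposite way, with hydroxy in place of hydrogen, and it is a 1.2-fold lower number from compound 1 to compound 3 (0.09 log units; within the scatter) and thus no real change. Within the data shown here, no compound without a hydroxy has been measured yet, so this evidence is thin. Even so, no shift beyond the scatter is expected in this assay for this change. The expected step is a 1.0-fold lower number from compound 2 to compound 4 (0.02 log units; within the scatter) and would be too small to read as a real difference. For compound 4 the estimated value is 5500 nM (expected range 2500 nM to 12000 nM).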

Compound 4, half-maximal inhibitory concentration: 4400 nM
Estimate against measurement, compound 4: 1.3-fold (0.10 log units) above, and the stated range covers the measured number.
By their numbers in this assay, from the lowest: compounds 3, 1, 4 and 2 (each within the scatter of the next).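

Within the data shown here, compound 4 carries no hydroxy at all, so it tests what the earlier compounds could not: whether activity depends on having a hydroxy on the six-membered aromatic ring. In this assay, hydrogen in place of the hydroxy ortho to a large group gives a 1.3-fold lower number from compound 2 to compound 4 (0.11 log units; within the scatter), and the same swap for the hydroxy of compound 1 gives a 1.0-fold higher number from compound 1 to compound 4 (0.02 log units; within the scatter), so neither removal shows a real change and a hydroxy is not required for numbers in this range. Adding or removing a hydroxy also reads alike across the two cores: the same change on two cores in this assay, a 1.2-fold lower number (0.09 log units; within the scatter) from compound 1 to compound 3 and a 1.3-fold higher number (0.11 log units; within the scatter) from compound 4 to compound 2, 1.6-fold (0.20 log units) apart, within the scatter of two such steps.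

Going by these compounds, whether a different group at this position, such as an amine, a methoxy group or a carboxylic acid, would shift the number beyond the scatter remains open. The same question stands for a fluorine on this ring.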